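The compounds below may be only part of what the source reports. "The series", "measured", "known", "first", "only" and "open" are said of these compounds alone.

Measured so far:
- compound 1, `COc1ccc(/C(=C(/CCCl)c2ccccc2)c2ccccc2)cc1`: in a functional assay on MCF7 cells (Homo sapiens) for cytotoxicity, read by MTT assay, with a stated time of 72 h (on this read-out lower numbers stand for stronger inhibition and higher numbers for weaker inhibition), compound 1 gives > 50000 nM, which is a limit of the assay rather than a number.
- compound 2, `COc1ccc(/C(=C(/CCNC(=O)NC2CCCCC2)c2ccccc2)c2ccccc2)cc1`: in this assay compound 2 gives 37200 nM.
- compound 3, `COc1ccc(/C(=C(/CCNC(=O)N2CCCC2)c2ccccc2)c2ccccc2)cc1`: in this assay compound 3 gives > 50000 nM, again a limit of the assay.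

Compound 3 thus stands at the limit, where two of the three values sit (the limit of > 50000 nM in this assay, at which 2 of the 3 values shown sit). Only compound 2 carries a number, and the step of an at least 1.3-fold higher number from compound 2 to compound 3 (0.12 log units; that floor lies within the scatter) is as far as the limit lets it be read. Likewise an at least 1.3-fold lower number from compound 1 to compound 2 (0.12 log units; that floor lies within the scatter) stays within the scatter, and a step that the two limits leave unreadable from compound 1 to compound 3 cannot be read at all.

Compound 4, `COc1ccc(/C(=C(/CCNC(=O)C(=O)NC2CCCCC2)c2ccccc2)c2ccccc2)cc1`, differs from compound 3 by cyclohexylcarbamoyl in place of pyrrolidin-1-yl on a carbonyl carbon. This restores the cyclohexylamino end seen in compound 2, now set on a second carbonyl. Going by the values given here, the steps that bear on it are an at least 1.3-fold higher number from compound 2 to compound 3 (0.12 log units; that floor lies within the scatter), read in reverse, and an at least 1.3-fold lower number from compound 1 to compound 2 (0.12 log units; that floor lies within the scatter); both sit within the scatter, so no step beyond the scatter is expected, although a return to a readable number near compound 2 is plausible. Compound 4 is therefore expected at about 40000 nM, within a range of 15000 nM to 100000 nM. That estimate amounts to an at least 1.2-fold lower number from compound 3 to compound 4 (0.09 log units; that floor lies within the scatter), which is expected to stay within the scatter.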

Compound 4, half-maximal inhibitory concentration: 12100 nM
Estimate against measurement, compound 4: 3.3-fold (0.52 log units) above; the whole stated range lies above it.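

In this assay, going by these compounds alone, the second carbonyl brings the first step that is certain to lie beyond the scatter: with cyclohexylcarbamoyl in place of cyclohexylamino on a carbonyl carbon, there is a 3.1-fold lower number from compound 2 to compound 4 (0.49 log units; beyond the scatter), so the cyclohexylamino end alone does not account for the gain. Against pyrrolidin-1-yl on a carbonyl carbon, cyclohexylcarbamoyl gives an at least 4.1-fold lower number from compound 3 to compound 4 (0.61 log units; beyond the scatter), and against the chloro end of the chain, the whole change gives an at least 4.1-fold lower number from compound 1 to compound 4 (0.61 log units; beyond the scatter). These last two steps are floors rather than sizes, since compound 1 and compound 3 each stand at a limit of the assay: the limit of > 50000 nM in this assay, at which 2 of the 4 values shown sit.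

The compounds shown do not tell whether the second carbonyl would bring the same gain with another end group, such as a morpholine or a phenyl ring in place of the cyclohexyl ring. Nor do they tell whether a longer chain leading to the amide nitrogen, or a free amine in place of the amide end, would lower the number further.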